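The source may hold more compounds than are shown below. What is called first, only, known or untested is meant among the compounds shown, and "the series" means these compounds.

- compound 1 (`CCC(CC)C(=O)OCC(C)(C)CC1=C(O)C(=O)c2ccccc2C1=O`) gives 104000 nM in the measurements so far
- compound 2 (`CCCCCCC(=O)OCC(C)(C)CC1=C(O)C(=O)c2ccccc2C1=O`) gives 99300 nM in the measurements so far

Both values come from an ADME assay on Vero cells (Chlorocebus sabaeus) for cytotoxicity, read by MTT assay (on this read-out lower numbers stand for stronger inhibition and higher numbers for weaker inhibition), and they sit within the scatter of each other, so compound 2 cannot be ranked against compound 1. Only these two numbers are available, and together they show one level rather than a trend.

Compound 3 (`CCCCCCCC(=O)OCC(C)(C)CC1=C(O)C(=O)c2ccccc2C1=O`) has not yet been measured. It differs from compound 2 by a single change (methyl in place of hydrogen on a saturated chain carbon, six bonds along the chain from a carbonyl carbon), which is methyl in place of hydrogen on a saturated chain carbon, six bonds along the chain from a carbonyl carbon.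

Going by the values given here, only one measured step bears on this change (a 1.0-fold lower number from compound 1 to compound 2 (0.02 log units; within the scatter)), in which hexyl takes the place of pentan-3-yl on a carbonyl carbon. That step also alters the chain on the carbonyl side and stays within the scatter. One step is thin evidence, but it gives no reason to expect a shift in either direction, so no step beyond the scatter is expected in this assay here. The expected step is small (a 1.0-fold lower number from compound 2 to compound 3 (0.02 log units; within the scatter)) and lies within the scatter. Compound 3 is therefore estimated at 95000 nM (range 50000 nM to 170000 nM).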

Compound 3, half-maximal inhibitory concentration: > 258000 nM
Compound 3 was reported as a limit; the forecaster's own chance of this, stated with the estimate: 10%; middle value at least 2.7-fold (0.43 log units) away from the limit.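

In this assay compound 3 carries a limit and not a number: the limit of > 258000 nM in this assay, at which 1 of the 3 values shown sits. Even so, methyl in place of hydrogen on a saturated chain carbon, six bonds along the chain from a carbonyl carbon, gives an at least 2.5-fold higher number from compound 2 to compound 3 (0.41 log units; beyond the scatter), the first step in this series beyond the scatter, and a longer replacement for pentan-3-yl on that carbonyl carbon gives an at least 2.4-fold higher number from compound 1 to compound 3 (0.39 log units; beyond the scatter), whereas hexyl in that same place gave only a 1.0-fold lower number from compound 1 to compound 2 (0.02 log units; within the scatter). Higher numbers here stand for weaker inhibition, so this position at the end of the chain is not silent: the change weakens inhibition in the Vero cell read-out, something the level pair of compound 1 and compound 2 could not reveal.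

Going by these compounds, because compound 3 is a limit, the true size of its step stays unknown, and so does whether the effect belongs to chain length as such or only to this one chain. The compounds shown also leave open how a longer chain, or an amine or a carboxylic acid at this chain end, would read in this assay.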